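Benzyl substituent swap in an oxadiazolone series

This account rests on a few compounds, and the source may have more. Where it says the series, first, only, none or still open, it means among the compounds named here.

Compound 3 `Cc1ccc(COc2ccc(-c3nn(CCC#N)c(=O)o3)cc2)cc1` carries the highest number of the three measured compounds in an assay for inhibition of Amine oxidase [flavin-containing] B (Rattus norvegicus) (on this read-out lower numbers stand for stronger inhibition and higher numbers for weaker inhibition), giving 15 nM; its nearest neighbour is compound 2 `Cc1cccc(COc2ccc(-c3nn(CCC#N)c(=O)o3)cc2)c1` with 8 nM, and the furthest is compound 1 `N#CCCn1nc(-c2ccc(OCc3ccccc3)cc2)oc1=O` with 2.2 nM. Compound 4 `N#CCCn1nc(-c2ccc(OCc3cccc(Cl)c3)cc2)oc1=O` differs from compound 3 by 3-chlorophenyl in place of 4-methylphenyl on a saturated chain carbon bound to an oxygen on an aromatic ring. The step most relevant here is a 1.9-fold higher number from compound 2 to compound 3 (0.27 log units; within the scatter), which moved the methyl between the two ring positions; the steps of a 3.6-fold higher number from compound 1 to compound 2 (0.56 log units; beyond the scatter) and a 6.8-fold higher number from compound 1 to compound 3 (0.83 log units; beyond the scatter) show what adding a methyl at either position cost. Since compound 2 with its 3-methylphenyl gave 8 nM, the 3-chlorophenyl of compound 4 is expected to land in that region, a step of a 1.9-fold lower number from compound 3 to compound 4 (0.27 log units; within the scatter) from compound 3, within or near the scatter. Compound 4 is therefore estimated at 8 nM, in the range 3 nM to 25 nM.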

Compound 4, half-maximal inhibitory concentration: 12 nM
Compound 4: middle estimate off by 1.5-fold (0.18 log units), on the low side; the measured number falls inside the stated range.
By their numbers in this assay, from the lowest: compound 1; then compounds 2, 4 and 3 (each within the scatter of the next).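

With the 3-chlorophenyl group, a substituent other than methyl joins the series, and it cannot be told apart from either methylphenyl group: the change gives a 1.3-fold lower number from compound 3 to compound 4 (0.10 log units; within the scatter) and, with chloro in place of methyl, a 1.5-fold higher number from compound 2 to compound 4 (0.18 log units; within the scatter). Chloro in place of hydrogen on the aromatic carbon still carries a cost, a 5.5-fold higher number from compound 1 to compound 4 (0.74 log units; beyond the scatter), so all three substituted compounds stand apart from compound 1. Nothing available explains this result. The compounds shown leave open whether a fluoro, a methoxy or an amine on this ring would carry the same cost.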